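Working notes on a serotonin receptor agonist series

The source may report more compounds than this note shows. Statements on the series, on what has been measured and on what is new or still open speak of the compounds shown alone.

Three compounds have been run in a functional assay on HEK293 cells for activation of 5-hydroxytryptamine receptor 4 (Homo sapiens), read by cAMP accumulation; on this read-out lower numbers stand for smaller maximal responses and higher numbers for larger maximal responses. Compound 3 `CCN1CCC(NC(=O)c2cc(Cl)c(N)cc2OC)CC1` reaches only a limit of the assay there, > 100%. Compound 1 `COc1cc(N)c(Cl)cc1C(=O)NCCN1CCNCC1` likewise sits at a limit in this assay, > 100%. Compound 2 `COc1ccc2[nH]cc(C(=O)NCC3CCNCC3)c2c1` gives a number, 42%. Compound 3 thus stands at the upper edge of what the read-out reports, together with one other value, since (the limit of > 100% in this assay, at which 2 of the 3 values shown sit). Among the compounds with values here, no pair of measured compounds differs in a single place, so the effect of a single substitution within this set has not been observed directly.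

Compound 4 `COc1cc(N)c(Cl)cc1C(=O)NC1CCN(CCN2CCCCC2)CC1` is the next candidate for this assay. It differs from compound 3 as follows: piperidin-1-yl in place of hydrogen on a saturated chain carbon, two bonds along the chain from an amine nitrogen in a ring. Compound 3 already stands at a limit, > 100%, so there is no room for a measurable rise. The step from compound 3 to compound 4 is expected to be none beyond the scatter, a number no higher from compound 3 to compound 4 (the limit leaves the size open). Compound 4 is estimated at 100%, within 80% to 115%, with a real chance that only a limit is reported again.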

Compound 4, intrinsic activity: the largest response reached, in percent of the reference agonist's: > 100%
Compound 4 ended at the assay's limit (the forecaster's own chance of this, stated with the estimate: 55%); the middle value lies on the limit itself.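

Compound 3 and compound 4 both stand at a limit in this assay, so no step between them can be read: the limit of > 100% in this assay, at which 3 of the 4 values shown sit.

The compounds shown leave open whether 2-(piperidin-1-yl)ethyl in place of ethyl changes the maximal response at all, and by how much.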